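Compound 3 to compound 4: oxan-4-yl to cyclohexyl

A few compounds are considered here, and "the series" means these few. Any claim that something is new, unique, unknown or untested is made for them only; others in the source may bear on it.

In a functional assay on Shh Light II cells (Mus musculus) for inhibition, read by a luciferase reporter (a higher number here means a weaker inhibitor, a lower number a stronger inhibitor), compound 1 `O=C(Nc1ccccc1Cl)N1CCC(c2nc(-c3ccc4ccccc4n3)no2)CC1` gives 510 nM and compound 2 `COc1ccccc1OC(=O)N1CCC(c2nc(-c3ccc4ccccc4n3)no2)CC1` gives 250 nM on the shared core. Compound 3 `O=C(NC1CCOCC1)N1CCC(c2nc(-c3ccc4ccccc4n3)no2)CC1` gives 480 nM and lies within the scatter of both. For the measured compounds named here, the only step beyond the scatter, and a modest one, is a 2.0-fold lower number from compound 1 to compound 2 (0.31 log units; beyond the scatter) with the change on the carbonyl carbon.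

Compound 4 `O=C(NC1CCCCC1)N1CCC(c2nc(-c3ccc4ccccc4n3)no2)CC1` carries cyclohexyl in place of oxan-4-yl on an amide-type nitrogen with the rest unchanged. On that same nitrogen, a 1.1-fold lower number from compound 1 to compound 3 (0.03 log units; within the scatter) for oxan-4-yl in place of 2-chlorophenyl. The change on the carbonyl carbon gives a 1.9-fold higher number from compound 2 to compound 3 (0.28 log units; within the scatter) and also stays within the scatter. Going by the values given here, no measured pair isolates oxan-4-yl against cyclohexyl, so the basis is thin.

In this assay no step beyond the scatter is therefore expected. The expected step is a 1.2-fold lower number from compound 3 to compound 4 (0.08 log units; within the scatter) on this reasoning. Compound 4 is estimated at 400 nM with an expected range from 170 nM to 900 nM in this series.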

Compound 4, half-maximal inhibitory concentration: 57 nM
For compound 4 the middle estimate is 7.0-fold (0.85 log units) above the measured one; measured number below the stated range.
By their numbers in this assay, from the lowest: compound 4; then compounds 2, 3 and 1 (each within the scatter of the next, the first and the last beyond it).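

In this assay the amide-type nitrogen no longer looks indifferent to its substituent: cyclohexyl in place of oxan-4-yl gives an 8.4-fold lower number from compound 3 to compound 4 (0.93 log units; beyond the scatter) even though both groups are six-membered non-aromatic rings of 6 heavy atoms, and the oxygen of oxan-4-yl is the only difference. Against the other two compounds the picture holds, with an 8.9-fold lower number from compound 1 to compound 4 (0.95 log units; beyond the scatter) for the change on that nitrogen and a 4.4-fold lower number from compound 2 to compound 4 (0.64 log units; beyond the scatter) for the change on the carbonyl carbon, which leaves compound 4 the most potent of the four. Nothing available explains the size of this step.

As far as these compounds go, whether the gain belongs to cyclohexyl alone or extends to other carbon-only groups remains open. Cyclopentyl, cycloheptyl, unsubstituted phenyl or an open hexyl chain on the same nitrogen would help separate these cases, as would a piperidin-4-yl group, which carries an amine in the ring.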